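Swapping the aryl on the pyridazinone nitrogen

This account rests on a few compounds, and the source may have more. Where it says the series, first, only, none or still open, it means among the compounds named here.

Measured so far in a functional assay on A549 cells (Homo sapiens) for cytotoxicity, read by MTT assay, with a stated time of 72 h; a lower number here means a stronger inhibitor, a higher number a weaker inhibitor:
- compound 1, `CNC(=O)c1cc(Oc2ccc(NC(=O)c3nn(-c4ccccc4OC(F)(F)F)c(=O)cc3C)cc2F)ccn1`: > 40000 nM
- compound 2, `Cc1cc(=O)n(-c2ccccc2OC(F)(F)F)nc1C(=O)Nc1ccc(Oc2ncnc3sccc23)cc1`: 15500 nM
- compound 3, `Cc1cc(=O)n(-c2ccc(Br)cc2F)nc1C(=O)Nc1ccc(Oc2ncnc3sccc23)c(F)c1`: 11500 nM

The value for compound 1 is a limit of this assay, not a number; compound 1 reached no measurable inhibition there. Among the two numbers, compound 3 has the lowest, and the nearest is compound 2, whose value lies within the scatter of repeated measurements, so the two cannot be ranked against each other.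

The next compound, compound 4, is `Cc1cc(=O)n(-c2ccccc2OC(F)(F)F)nc1C(=O)Nc1ccc(Oc2ncnc3sccc23)c(F)c1`. It arises from compound 3 by a single change: 2-(trifluoromethoxy)phenyl in place of 4-bromo-2-fluorophenyl on an aromatic nitrogen. Everything else in the structure stays the same, including the fluorine on the anilide ring that compound 3 carries and compound 2 lacks.

Among the measured compounds shown here, no step between measured compounds is available, so the expectation must rest on the values themselves. Compound 2 already carries the 2-(trifluoromethoxy)phenyl group that enters here and gives 15500 nM, a number within the scatter of compound 3. On that basis the step of a 1.1-fold higher number from compound 3 to compound 4 (0.05 log units; within the scatter) is expected to stay within the scatter, with no clear direction. Compound 4 is estimated at 13000 nM, within a range from 5000 nM to 35000 nM.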

Compound 4, half-maximal inhibitory concentration: > 40000 nM
Compound 4 gave a limit, no number; the forecaster's own chance of this, stated with the estimate: 15%; at least 3.0-fold (0.48 log units) between middle value and limit.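

Among the compounds shown here, with the rest of the structure unchanged, putting 2-(trifluoromethoxy)phenyl in place of 4-bromo-2-fluorophenyl on the aromatic nitrogen gives an at least 3.4-fold higher number from compound 3 to compound 4 (0.54 log units; beyond the scatter) in this assay, so the choice of aryl group at this position clearly counts here, something no single-place comparison among the earlier compounds could show. The fluorine on the anilide ring also counts: with the 2-(trifluoromethoxy)phenyl group kept, fluoro in place of hydrogen on an aromatic carbon gives an at least 2.5-fold higher number from compound 2 to compound 4 (0.41 log units; beyond the scatter), a weaker result in this assay with the fluorine present. Both steps are minimum sizes and the step between compound 1 and compound 4 cannot be read, because compound 4 gave a limit of the assay rather than a number: the limit of > 40000 nM in this assay, at which 2 of the 4 values shown sit.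

The two aryl groups differ in more than one feature, so the compounds shown do not reveal whether the bromine, the ring fluorine or the trifluoromethoxy group accounts for the step. A plain phenyl, a 4-bromophenyl or an aryl ring carrying an amine on the same nitrogen would help to separate these contributions.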